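The source may report more compounds than this note shows. Statements on the series, on what has been measured and on what is new or still open speak of the compounds shown alone.

Three compounds have values in a functional assay on HeLa cells (Homo sapiens) for antiproliferative activity, read by MTT assay; a lower number here means a stronger inhibitor, a higher number a weaker inhibitor. Compound 1 (`COc1ccc(-c2ccnc(Nc3ccc([N+](=O)[O-])cc3)n2)cc1`) gives 980 nM and compound 3 (`Clc1ccc(Nc2nccc(-c3ccc(Br)cc3)n2)c(Cl)c1`) gives 1080 nM, two values within the scatter of each other, while compound 2 (`Cc1cccc(Nc2nccc(-c3ccc(Br)cc3)n2)c1`) stands far off at 71000 nM. Compound 4 (`O=[N+]([O-])c1ccc(Nc2nccc(-c3ccc(Br)cc3)n2)cc1`) departs from compound 1 in one place: bromo in place of methoxy on an aromatic carbon. Among the measured compounds shown here, no measured pair isolates this change. The 4-bromophenyl group appears in compound 3 at 1080 nM and in compound 2 at 71000 nM, so the evidence is loose. A small rise in this assay is expected, possibly none beyond the scatter. The estimated change is a 1.5-fold higher number from compound 1 to compound 4 (0.18 log units; within the scatter). For compound 4 the expected value is 1500 nM, within an estimated range of 400 nM to 6000 nM.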

Compound 4, half-maximal inhibitory concentration: 25700 nM
Estimate against measurement, compound 4: 17-fold (1.23 log units) below, outside the stated range (above it).
By their numbers in this assay, from the lowest: compounds 1 and 3 (each within the scatter of the next); then compound 4; then compound 2.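

In this assay the change from 4-methoxyphenyl to 4-bromophenyl gives a 26-fold higher number from compound 1 to compound 4 (1.42 log units; beyond the scatter) and shows that this position, on an aromatic carbon para to a large group, is sensitive to the exchange of methoxy for bromo. Among the compounds shown here, the earlier compounds held no pair differing in one place, so this is the first direct reading of the change. No available measurement bears on the origin of this step. Still open, as far as these compounds go, is whether a hydroxyl group, an amine or a longer ether chain here would stay near compound 1 or fall toward compound 4. Also open, from the compounds shown here alone, is whether the step keeps its size with a different group elsewhere on the core.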